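The source may report more compounds than this note shows. Statements on the series, on what has been measured and on what is new or still open speak of the compounds shown alone.

Measured in a functional assay on SK-MEL-28 cells (Homo sapiens) for inhibition, read by MTT assay, with a stated time of 72 h; on this read-out higher numbers stand for weaker inhibition and lower numbers for stronger inhibition:
Compound 1 `C[C@]12O[C@@H]1CC[C@@]1(C)O[C@@H]1[C@H]1OC(=O)[C@@H](CN3CCN(c4ccccc4)CC3)[C@@H]1C[C@H]2O`: 51000 nM
Compound 2 `C[C@]12O[C@@H]1CC[C@@]1(C)O[C@@H]1[C@H]1OC(=O)[C@@H](CN3CCN(c4ccccc4F)CC3)[C@@H]1C[C@H]2O`: 17000 nM

Compound 2 holds the lower of the two numbers and is the stronger inhibitor of this pair. Compound 3 `C[C@]12O[C@@H]1CC[C@@]1(C)O[C@@H]1[C@H]1OC(=O)[C@@H](CN3CCN(c4ccc(Cl)cc4)CC3)[C@@H]1C[C@H]2O` has not yet been measured. It differs from compound 2 as follows: 4-chlorophenyl in place of 2-fluorophenyl on an amine nitrogen in a ring. In words, it has 4-chlorophenyl in place of 2-fluorophenyl on an amine nitrogen in a ring. Among the measured compounds shown here, only one measured step bears on this change, fluoro in place of hydrogen on an aromatic carbon, which gave a 3.0-fold lower number from compound 1 to compound 2 (0.48 log units; beyond the scatter). For the measured compounds named here, that step is modest, and none of the measured compounds shows one such substituted phenyl exchanged for another. In this assay, therefore, no step beyond the scatter is expected, and no direction can be firmly expected. The expected step is a 1.2-fold higher number from compound 2 to compound 3 (0.07 log units; within the scatter). Compound 3 is estimated at 20000 nM, with an expected range from 8000 nM to 50000 nM.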

Compound 3, half-maximal inhibitory concentration: 31000 nM
Beside the measured number, compound 3's estimate is 1.6-fold (0.19 log units) below it; low and high end bracket the measured number.
By their numbers in this assay, from the lowest: compounds 2, 3 and 1 (each within the scatter of the next, the first and the last beyond it).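

In this assay, 4-chlorophenyl on the amine nitrogen in the ring, in place of 2-fluorophenyl, gives a number within the scatter of compound 2 (a 1.8-fold higher number from compound 2 to compound 3 (0.26 log units; within the scatter)). Adding chloro to the unsubstituted phenyl also stays within the scatter (a 1.6-fold lower number from compound 1 to compound 3 (0.22 log units; within the scatter)), whereas the fluoro exchange on the unsubstituted phenyl lies beyond it (a 3.0-fold lower number from compound 1 to compound 2 (0.48 log units; beyond the scatter)), so only the step to compound 2 separates clearly from the parent compound 1. Nothing available explains these numbers or says what the halogens contribute.

Compound 3 differs from compound 2 in both the halogen and where it sits on the phenyl, so these two changes cannot be told apart here. On these data alone, whether a methoxy group or a nitrile on the phenyl, or a benzyl group in its place, would give a step beyond the scatter remains open.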